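Thiophen-2-yl in Place of the Methoxybenzyl Arm

The source may hold more compounds than are shown below. What is called first, only, known or untested is meant among the compounds shown, and "the series" means these compounds.

Of the compounds shown here, three on a shared core have been measured in a functional assay on FM3A cells (Mus musculus) for inhibition, read by cell counting, with a stated time of 2 days; a lower number here means a stronger inhibitor, a higher number a weaker inhibitor. Compound 1 `C=C(Br)C(=O)Nc1cccc(-c2cn3nc(-c4ccc(OC)c(OC)c4)sc3n2)c1` gives 110 nM, compound 2 `Nc1cccc(-c2cn3nc(Cc4ccc(Cl)cc4)sc3n2)c1` gives 6000 nM, and compound 3 `C=C(Br)C(=O)Nc1cccc(-c2cn3nc(Cc4ccc(OC)cc4)sc3n2)c1` gives 850 nM, which leaves compound 3 second highest of the three, beyond the scatter from both of the others. Within the data shown here, the one single-site step known, a 7.7-fold higher number from compound 1 to compound 3 (0.89 log units; beyond the scatter), shows that 4-methoxybenzyl in place of 3,4-dimethoxyphenyl raised the number modestly. Compound 4 `C=C(Br)C(=O)Nc1cccc(-c2cn3nc(-c4cccs4)sc3n2)c1` differs from compound 3 by thiophen-2-yl in place of 4-methoxybenzyl on an aromatic carbon, so an aromatic ring rather than a benzyl again sits at that carbon, as in compound 1. Because a 7.7-fold higher number from compound 1 to compound 3 (0.89 log units; beyond the scatter) ran the other way, a modest fall is expected, a 3.4-fold lower number from compound 3 to compound 4 (0.53 log units; beyond the scatter). Compound 4 is therefore estimated at 250 nM, within 80 nM to 800 nM.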

Compound 4, half-maximal inhibitory concentration: 370 nM
Compound 4: the middle estimate sits 1.5-fold (0.17 log units) below what was measured; the range from low to high includes it.
By their numbers in this assay, from the lowest: compound 1; then compound 4; then compound 3; then compound 2.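

Thiophen-2-yl in place of 4-methoxybenzyl gives a 2.3-fold lower number from compound 3 to compound 4 (0.36 log units; beyond the scatter), so a five-membered aromatic ring with 1 hetero atom at this carbon gives a lower number than the benzyl arm. It still falls short of 3,4-dimethoxyphenyl, with a 3.4-fold higher number from compound 1 to compound 4 (0.53 log units; beyond the scatter), so having an aromatic ring at this carbon does not alone set the number. No measured evidence bears on why these numbers differ. Still open, on these data alone, is how an unsubstituted phenyl, or a thiophene carrying an amine or a carboxylic acid, would compare at this carbon.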